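A ketone in place of a hydroxypropyl on the shared core

The source may hold more compounds than are shown below. What is called first, only, known or untested is meant among the compounds shown, and "the series" means these compounds.

Three compounds share one core and differ only in the group on the fused six-membered carbon ring. Compound 1 `CCn1c(CNc2ccccc2)nnc1SCc1nc2cc(Cl)ccc2o1` carries chloro there, and in an ADME assay on blood (Rattus norvegicus) for metabolic stability, with a stated time of 2 h (on this read-out lower numbers stand for a less stable compound and higher numbers for a more stable compound), compound 1 gives 92%. Compound 2 `CCn1c(CNc2ccccc2)nnc1SCc1nc2cc(OC(F)(F)F)ccc2o1` carries trifluoromethoxy, and in this assay compound 2 gives 100%. Compound 3 `CCC(O)c1ccc2oc(CSc3nnc(CNc4ccccc4)n3CC)nc2c1` carries 1-hydroxypropyl, and in this assay compound 3 gives 80%, the lowest of the three numbers. Between compounds 1 and 2 the step is small: a number 8 percentage points higher from compound 1 to compound 2 (within the scatter).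

Compound 4 `CCn1c(CNc2ccccc2)nnc1SCc1nc2cc(C(=O)C(C)C)ccc2o1` awaits measurement. Its change from compound 3 is isopropylcarbonyl in place of 1-hydroxypropyl on an aromatic carbon. The two measured steps that bear on it are those leading into compound 3, a number 12 percentage points lower from compound 1 to compound 3 (beyond the scatter) and a number 20 percentage points lower from compound 2 to compound 3 (beyond the scatter), both modest falls when 1-hydroxypropyl entered. Taking 1-hydroxypropyl away again points toward a modest rise, but no measured compound carries isopropylcarbonyl, so the expectation is uncertain. For compound 4 in this assay the expected value is 86%, within a range from 72% to 100%. That estimate means an expected step of a number 6 percentage points higher from compound 3 to compound 4 (within the scatter), near the edge of the scatter.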

Compound 4, percent of the compound remaining: 42%
Compound 4: the middle estimate sits 44 percentage points above what was measured; the measured number lies below the stated range.
By their numbers in this assay, from the lowest: compound 4; then compound 3; then compounds 1 and 2 (each within the scatter of the next).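

Swapping 1-hydroxypropyl for isopropylcarbonyl in this assay gives a number 38 percentage points lower from compound 3 to compound 4 (beyond the scatter) and shows that this position on the shared core can shift the read-out far more than the earlier modest steps suggested. The same picture holds against the two other groups, with a number 50 percentage points lower from compound 1 to compound 4 (beyond the scatter) for chloro and a number 58 percentage points lower from compound 2 to compound 4 (beyond the scatter) for trifluoromethoxy, so a stable result with those groups or with 1-hydroxypropyl does not carry over to every group placed here. Nothing available explains this fall.

As far as these compounds go, compound 4 differs from compound 3 in both the carbonyl and the isopropyl chain, so it remains open which of the two goes with the lower number. An alcohol bearing the same isopropyl chain, or an acetyl group, would separate the two, and an amide or a carboxylic acid here remains an open case.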